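Amide side-chain exchange on the shared core

The compounds below may be only part of what the source reports. "The series", "measured", "known", "first", "only" and "open" are said of these compounds alone.

compound 1 `CC(C)C[C@H](N)c1cc(C(F)(F)F)ccc1N1CCN(C(=O)CCNC2CCCCC2)CC1` — 4800 nM
compound 2 `CC(C)C[C@H](N)c1ccccc1N1CCN(C(=O)[C@H](C)Cc2ccc(Cl)cc2Cl)CC1` — 16 nM

In an assay on HEK293 cells for displacement of a labelled ligand from Melanocortin receptor 4 (Homo sapiens) (a lower number here means a stronger inhibitor, a higher number a weaker inhibitor), compound 1 gives the higher of the two numbers; the number of compound 2 is far lower, well beyond the scatter. Compound 3 `CCOc1cccc(CC(C)C(=O)N2CCN(c3ccc(C(F)(F)F)cc3[C@@H](N)CC(C)C)CC2)c1` differs from compound 1 in one place: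

1-(3-ethoxybenzyl)ethyl in place of 2-(cyclohexylamino)ethyl on a carbonyl carbon

Within the data shown here, no measured pair isolates this exchange. Compound 2 carries a different group at the same carbonyl carbon and gives the lower number, and that is the only pointer available here. A large drop in number is expected, an 80-fold lower number from compound 1 to compound 3 (1.90 log units; beyond the scatter). For compound 3 the estimate is 60 nM, with a range from 10 nM to 400 nM.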

Compound 3, inhibition constant: 2200 nM
The estimate for compound 3 lay 37-fold (1.56 log units) below the measured number; measured number outside the range, above it.
By their numbers in this assay, from the lowest: compound 2; then compound 3; then compound 1.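

In this assay, putting 1-(3-ethoxybenzyl)ethyl in place of 2-(cyclohexylamino)ethyl on a carbonyl carbon gives a 2.2-fold lower number from compound 1 to compound 3 (0.34 log units; beyond the scatter) and no more. At this position, on this core, losing the side-chain amine and gaining an aromatic ring is a real but modest change, and compound 3 still stands at 2200 nM in this series. Nothing at hand bears on the reason for this step.

Open, going by these compounds, is how this position responds to other groups on the core of compound 1, such as a carboxylic acid or a longer chain ending in a primary amine. Also open, on these data alone, is what part the trifluoromethyl group plays in the number of compound 3.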